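Thiocarbamate amines on a shared chromone core

The compounds below may be only part of what the source reports. "The series", "measured", "known", "first", "only" and "open" are said of these compounds alone.

Measured compounds:
compound 1 `COc1ccc2occ(CSC(=S)N(C(C)C)C(C)C)c(=O)c2c1`: > 40000 nM
compound 2 `O=c1c(CSC(=S)N2CCN(c3ccccc3)CC2)coc2ccccc12`: > 30000 nM
compound 3 `CN1CCN(C(=S)SCc2coc3ccccc3c2=O)CC1`: 22900 nM

Among the compounds with values here, in a functional assay on MCF7 cells (Homo sapiens) for antiproliferative activity, read by MTT assay, with a stated time of 72 h (a higher number here means a weaker inhibitor, a lower number a stronger inhibitor), compound 3 gives 22900 nM, the only actual number among the three. For compound 1 the assay reports only a limit, > 40000 nM. For compound 2 likewise only a limit is reported, > 30000 nM. Within the data shown here, the one measured step, an at least 1.3-fold lower number from compound 2 to compound 3 (0.11 log units; that floor lies within the scatter), sits within the scatter and concerns the substituent on the ring nitrogen, not the amine itself.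

Compound 4 `CC(C)N(C(=S)SCc1coc2ccccc2c1=O)C(C)C` differs from compound 3 by diisopropylamino in place of 4-methylpiperazin-1-yl on a thiocarbonyl carbon. Among the measured compounds shown here, no measured step covers this exchange of the whole amine. What can be drawn on is compound 1, whose thiocarbonyl carbon also bears diisopropylamino and which reaches only the limit (the limit of > 40000 nM in this assay, at which 1 of the 3 values shown sits). Compound 3 with the piperazine gives 22900 nM. On that basis compound 4 is expected to stay at the weak end, with an expected step of a 1.5-fold higher number from compound 3 to compound 4 (0.18 log units; within the scatter) and a fair chance that it too would only reach a limit. The estimate for compound 4 is 35000 nM, between 15000 nM and 80000 nM.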

Compound 4, half-maximal inhibitory concentration: > 30000 nM
Compound 4 was reported as a limit; the forecaster's own chance of this, stated with the estimate: 55%; the middle value does not contradict the limit.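

Within the data shown here, the new result gives the first step that changes the whole amine on the thiocarbonyl carbon, not just a substituent on the ring nitrogen: in this assay, diisopropylamino in place of 4-methylpiperazin-1-yl gives an at least 1.3-fold higher number from compound 3 to compound 4 (0.11 log units; that floor lies within the scatter). That floor does not separate the two amines, so the open-chain amine and the piperazine cannot be put in order here. Compound 4 stands only as a limit, and it shares that limit with another compound: the limit of > 30000 nM in this assay, at which 2 of the 4 values shown sit.

From the compounds shown here alone, the step that removes the methoxy group joins two limits and cannot be read, so the part played by that group stays open. The compounds shown also do not tell whether a morpholine or a piperidine on the thiocarbonyl carbon would give a value clearly apart from that of compound 3.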